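The source may hold more compounds than are shown below. What is called first, only, known or untested is meant among the compounds shown, and "the series" means these compounds.

Working notes on the series.

Compound 2 `CCCNC(=O)OC[C@H]1OC(n2cnc3c(NC4CCOC4)ncnc32)[C@H](O)[C@@H]1O` gives 235 nM in an assay on DDT1 cells (Cricetulus griseus) for binding affinity to adenosine receptor A1 (Homo sapiens), read by radioligand binding; on this read-out higher numbers stand for weaker inhibition and lower numbers for stronger inhibition. Among the three measured compounds it stands at the highest number, with compound 1 nearest and compound 3 furthest. Compound 1 `CCNC(=O)OC[C@H]1OC(n2cnc3c(NC4CCOC4)ncnc32)[C@H](O)[C@@H]1O` gives 167 nM in this assay, and the step of a 1.4-fold higher number from compound 1 to compound 2 (0.15 log units; within the scatter) shows that exchanging the ethyl for a propyl on the carbamate nitrogen leaves the number where it was. Compound 3 `CC(C)/N=C(\S)OC[C@H]1OC(n2cnc3c(NC4CCOC4)ncnc32)[C@H](O)[C@@H]1O` gives 36 nM in this assay.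

Compound 4 `O[C@@H]1[C@@H](CO/C(S)=N/C2CCCCC2)OC(n2cnc3c(NC4CCOC4)ncnc32)[C@@H]1O` has not been measured in this assay. The change from compound 2 is a group of 9 heavy atoms (7 carbon, 1 nitrogen, 1 sulfur; one six-membered non-aromatic ring of carbon only) in place of a group of 6 heavy atoms (4 carbon, 1 nitrogen, 1 oxygen; no ring), on an oxygen on a saturated carbon. The entering group therefore carries the sulfur-bearing arrangement of compound 3, with a six-membered ring of carbon in place of the branched chain. Among the measured compounds shown here, the steps that bear on this are a 4.6-fold lower number from compound 1 to compound 3 (0.67 log units; beyond the scatter) and a 6.5-fold lower number from compound 2 to compound 3 (0.81 log units; beyond the scatter), both modest but beyond the scatter, and both in the direction of a lower number when the sulfur-bearing group replaces the carbamate. For the measured compounds named here, no measured pair shows what the six-membered ring of carbon itself does in place of a smaller chain, so that part of the change is unanchored. The expected step is a 5.9-fold lower number from compound 2 to compound 4 (0.77 log units; beyond the scatter), towards a lower number. Compound 4 is estimated at 40 nM, within a range of 12 nM to 130 nM.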

Compound 4, inhibition constant: 253 nM
Beside the measured number, compound 4's estimate is 6.3-fold (0.80 log units) below it; the measured number lies above the stated range.
By their numbers in this assay, from the lowest: compound 3; then compounds 1, 2 and 4 (each within the scatter of the next).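

Among the compounds shown here, the step of a 7.0-fold higher number from compound 3 to compound 4 (0.85 log units; beyond the scatter) is the first read at the double-bonded nitrogen in this assay, and it shows that cyclohexyl in place of isopropyl there is enough to undo the modest gain seen with compound 3. Compound 4 also stands level with both carbamates, with a 1.1-fold higher number from compound 2 to compound 4 (0.03 log units; within the scatter) and a 1.5-fold higher number from compound 1 to compound 4 (0.18 log units; within the scatter) both within the scatter, so the sulfur-bearing arrangement does not go with a lower number on its own: compound 3 shows that pattern and compound 4 goes against it. No measurement at hand accounts for this result.

The compounds shown leave open how the number moves between isopropyl and cyclohexyl on the double-bonded nitrogen, and a cyclopentyl, tert-butyl or phenyl group there would show whether the rise follows ring, branching or size of the group. They also leave open what the sulfur-bearing arrangement contributes apart from its substituent, which a carbamate with isopropyl or cyclohexyl on its nitrogen would set directly against compound 3 and compound 4.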